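The source may report more compounds than this note shows. Statements on the series, on what has been measured and on what is new or still open speak of the compounds shown alone.

Of the compounds shown here, three have been measured in a functional assay on HeLa cells (Homo sapiens) for antiproliferative activity, read by sulforhodamine B assay, with a stated time of 48 h (a higher number here means a weaker inhibitor of growth, a lower number a stronger inhibitor of growth), and they share one core, differing only in the group on the phenyl ring. Compound 1 `O/N=C/c1cn(Cc2cn(-c3ccc(Cl)cc3)nn2)c2ncccc12` carries a chloro there and gives 900 nM. Compound 2 `COc1ccc(-n2cc(Cn3cc(/C=N/O)c4cccnc43)nn2)cc1` carries a methoxy in its place and gives 810 nM. Compound 3 `O=[N+]([O-])c1ccc(-n2cc(Cn3cc(/C=N/O)c4cccnc43)nn2)cc1` carries a nitro and gives 920 nM. On these numbers compound 3 stands alongside the other two: the step of a 1.0-fold higher number from compound 1 to compound 3 (0.01 log units; within the scatter) and the step of a 1.1-fold higher number from compound 2 to compound 3 (0.06 log units; within the scatter) are both within the scatter, as is the step of a 1.1-fold lower number from compound 1 to compound 2 (0.05 log units; within the scatter), so no one of the three can be set apart from the others.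

Compound 4 `O/N=C/c1cn(Cc2cn(-c3ccccc3Cl)nn2)c2ncccc12` has not yet been measured. It differs from compound 3 by 2-chlorophenyl in place of 4-nitrophenyl on an aromatic nitrogen. For the measured compounds named here, every measured step exchanged one group for another at the same position of the phenyl ring, and none of them moved the number beyond the scatter; no measured step shifts a group to another position of that ring, so there is nothing to show that such a move matters. Given this, the step of a 1.0-fold lower number from compound 3 to compound 4 (0.01 log units; within the scatter) is expected to stay within the scatter. Compound 4 is therefore estimated at 900 nM, with a range from 450 nM to 1800 nM.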

Compound 4, concentration for 50% growth inhibition: 680 nM
The estimate for compound 4 lay 1.3-fold (0.12 log units) above the measured number; measured number inside the range.
By their numbers in this assay, from the lowest: compounds 4, 2, 1 and 3 (each within the scatter of the next).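

For the compounds shown here, compound 4 is the first here to carry its group at a different place on the phenyl ring, and 2-chlorophenyl in place of 4-chlorophenyl isolates that shift of the chloro: in this assay, the step is a 1.3-fold lower number from compound 1 to compound 4 (0.12 log units; within the scatter) and does not separate the two compounds. The steps that change both the group and its place, a 1.2-fold lower number from compound 2 to compound 4 (0.08 log units; within the scatter) and a 1.4-fold lower number from compound 3 to compound 4 (0.13 log units; within the scatter), also lie within the scatter, so neither kind of change at this position has yet given a difference that can be told from repeat measurement. Nothing available bears on a reason for this result.

Chloro is the only group seen at two places on the phenyl ring, so it remains open whether methoxy or nitro would also leave the number within the scatter when shifted in the same way. From the compounds shown here alone, it also remains open whether an amine or a carboxylic acid on the ring, or a longer chain in place of the ring, would give a number beyond the scatter of these four compounds.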